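Removing the bromine from the aryl group of compound 3

A few compounds are considered here, and "the series" means these few. Any claim that something is new, unique, unknown or untested is made for them only; others in the source may bear on it.

Compound 1 `COc1cc(-c2nc(SCc3cn(CC(=O)NC(=O)Nc4ccccn4)nn3)nc(Nc3ccc(C)cc3)c2C#N)cc(OC)c1OC` — 21300 nM
Compound 2 `Cc1ccc(Nc2nc(SCc3cn(CC(=O)NC(=O)Nc4ccccn4)nn3)nc(-c3ccc(C)cc3)c2C#N)cc1` — > 64000 nM, a limit of the assay and not a number
Compound 3 `Cc1ccc(Nc2nc(SCc3cn(CC(=O)NC(=O)Nc4ccccn4)nn3)nc(-c3ccc(Br)cc3)c2C#N)cc1` — 7920 nM

In a functional assay on ECa-109 cells (Homo sapiens) for inhibition, read by MTT assay, with a stated time of 72 h (on this read-out higher numbers stand for weaker inhibition and lower numbers for stronger inhibition), compound 3 stands lowest of the two numbers shown, with the remaining entry only a limit. The nearest measured step was a 2.7-fold lower number from compound 1 to compound 3 (0.43 log units; beyond the scatter). Compound 4 `Cc1ccc(Nc2nc(SCc3cn(CC(=O)NC(=O)Nc4ccccn4)nn3)nc(-c3ccccc3)c2C#N)cc1` differs from compound 3 by hydrogen in place of bromo on an aromatic carbon. Among the compounds with values here, no measured step exchanges a group for hydrogen, but the swap at the same carbon, an at least 8.0-fold lower number from compound 2 to compound 3 (0.90 log units; beyond the scatter), shows that this position matters, and the exchange of bromo for methyl ran against the limit (the limit of > 64000 nM in this assay, at which 1 of the 3 values shown sits). A step toward weaker inhibition, of modest size, is therefore expected, a 2.8-fold higher number from compound 3 to compound 4 (0.44 log units; beyond the scatter). Compound 4 is estimated at 22000 nM, between 8000 nM and 64000 nM.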

Compound 4, half-maximal inhibitory concentration: 24600 nM
Beside the measured number, compound 4's estimate is 1.1-fold (0.05 log units) below it; the range from low to high includes it.
By their numbers in this assay, from the lowest: compound 3; then compounds 1 and 4 (each within the scatter of the next). At a limit, above all of these: compound 2.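

The bromine does contribute to inhibition at this carbon, as there is now a hydrogen baseline for it (a 3.1-fold higher number from compound 3 to compound 4 (0.49 log units; beyond the scatter)). Methyl falls on the opposite side of that baseline (an at least 2.6-fold lower number from compound 2 to compound 4 (0.41 log units; beyond the scatter)), and the value of compound 2 is a limit of the assay, not a number: the limit of > 64000 nM in this assay, at which 1 of the 4 values shown sits. Plain phenyl and 3,4,5-trimethoxyphenyl cannot be told apart (a 1.2-fold higher number from compound 1 to compound 4 (0.06 log units; within the scatter)).

On these data alone, whether chloro, iodo, an amine or a carboxylic acid at this carbon would follow bromo, hydrogen or methyl remains open. The compounds shown also do not explain why bromo and methyl differ.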